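This account rests on a few compounds, and the source may have more. Where it says the series, first, only, none or still open, it means among the compounds named here.

Compound 3 `CCO/N=C(\CCN1CCN(c2ncccc2C#N)CC1)c1ccccc1` stands highest of the three measured compounds in a functional assay on HEK293 cells with D(4) dopamine receptor (Homo sapiens) as the target, read by FLIPR (on this read-out higher numbers stand for larger maximal responses and lower numbers for smaller maximal responses), giving 64%. Compound 1 `CCO/N=C(\CCN1CCN(c2cccc(OC)c2)CC1)c1ccccc1` gives 30%, and compound 2 `CCO/N=C(\CCN1CCN(c2ccc(OC)cc2)CC1)c1ccccc1` gives 5%. Compound 4 `CCO/N=C(\CCN1CCN(c2nccs2)CC1)c1ccccc1` differs from compound 3 by 1,3-thiazol-2-yl in place of 3-cyanopyridin-2-yl on an amine nitrogen in a ring. The two steps that bear on this change are both swaps of the group on the amine nitrogen in the ring: a number 34 percentage points higher from compound 1 to compound 3 (beyond the scatter) and a number 59 percentage points higher from compound 2 to compound 3 (beyond the scatter). Both show that this group moves the maximal response a great deal, so a step beyond the scatter is expected, most likely downward, since the 3-cyanopyridin-2-yl group of compound 3 gave the top value 64% among these. Compound 4 is therefore estimated at 45%, within 20% to 70%, an expected a number 19 percentage points lower from compound 3 to compound 4 (beyond the scatter).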

Compound 4, largest response reached (reported as efficacy), in percent of the reference or control that the assay uses: 72%
Compound 4: the middle estimate sits 27 percentage points below what was measured, and the stated range ends below it.
By their numbers in this assay, from the lowest: compound 2; then compound 1; then compounds 3 and 4 (each within the scatter of the next).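

In this assay, 1,3-thiazol-2-yl on the amine nitrogen in a ring gives a number 8 percentage points higher from compound 3 to compound 4 (within the scatter), so a high maximal response at this position does not require the six-membered ring or the nitrile of 3-cyanopyridin-2-yl. Compared with the two methoxyphenyl groups, it gives a number 67 percentage points higher from compound 2 to compound 4 (beyond the scatter) and a number 42 percentage points higher from compound 1 to compound 4 (beyond the scatter), placing both nitrogen-containing aromatic groups clear of them. No measurement given here explains these differences.

The compounds shown leave open whether the nitrile matters within the six-membered ring, as a plain pyridin-2-yl group would test. They also leave open whether the sulfur matters, as a 1,3-oxazol-2-yl group would test.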